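A few compounds are considered here, and "the series" means these few. Any claim that something is new, unique, unknown or untested is made for them only; others in the source may bear on it.

Of the compounds shown here, three of one family have so far been tested in an assay on isolated protein (urine) for inhibition of Myeloperoxidase (Homo sapiens), with a stated time of 5 min; a lower number here means a stronger inhibitor, a higher number a weaker inhibitor. Compound 1 `NCCCc1c[nH]c2c(F)cccc12` gives 24 nM. Compound 2 `N#CCCCc1c[nH]c2ccc(F)cc12` gives 63 nM, and compound 3 `NC(=O)CCCCc1c[nH]c2ccc(F)cc12` gives 39 nM. On these three numbers compound 3 stands second highest, but its gaps to both neighbours fall within the scatter: the nearest value belongs to compound 2 and the furthest to compound 1, and neither gap can be read as a real difference.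

Compound 4 `ONCCCc1c[nH]c2ccc(F)cc12` has not yet been measured. It differs from compound 3 in one place: hydroxyamino in place of carbamoylmethyl on a saturated chain carbon, three bonds along the chain from an aromatic carbon. Within the data shown here, only one measured step touches this part of the molecule, the one from compound 2 to compound 3, where a 1.6-fold lower number from compound 2 to compound 3 (0.21 log units; within the scatter); that exchange of one chain tail for another changed little. Among the measured compounds shown here, nothing measured yet shows how a hydroxyamino group on this chain behaves, so that single step is the only guide, and it points to a number close to that of compound 3.

Compound 4 is therefore estimated at 50 nM, with a range from 20 nM to 130 nM. The step this estimate implies, a 1.3-fold higher number from compound 3 to compound 4 (0.11 log units; within the scatter), is expected to stay within the scatter.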

Compound 4, half-maximal inhibitory concentration: 11 nM
Estimate against measurement, compound 4: 4.5-fold (0.66 log units) above; the measured number lies below the stated range.
By their numbers in this assay, from the lowest: compound 4; then compounds 1, 3 and 2 (each within the scatter of the next, the first and the last beyond it).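

The earlier step between compound 2 and compound 3 suggested that the group at the end of this chain mattered little, but hydroxyamino on a saturated chain carbon, three bonds along the chain from an aromatic carbon, shows otherwise. In this assay the change gives a 3.5-fold lower number from compound 3 to compound 4 (0.55 log units; beyond the scatter) and, measured against the nitrile, a 5.7-fold lower number from compound 2 to compound 4 (0.76 log units; beyond the scatter), so both steps lie beyond the scatter, although both are modest in size. The exchange for carbamoylmethyl replaces a group of 4 heavy atoms with one of 2 and raises the hydrogen-bond donors from 1 to 2, but these compounds cannot separate those differences, and no measurement here explains the lower number.

The compounds shown leave open how much of the gain depends on the free hydroxyl of the hydroxyamino group, which a methoxyamino group at the same place would test. They also leave open whether a carboxylic acid at this place, or a longer chain carrying hydroxyamino, would keep a number as low as that of compound 4.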